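Methoxy addition on the aniline ring of the quinoxaline sulfone series

The source may hold more compounds than are shown below. What is called first, only, known or untested is meant among the compounds shown, and "the series" means these compounds.

Going by the values given here, compound 2 `COc1ccc(S(=O)(=O)c2nc3ccccc3nc2Nc2cc(OC)cc(OC)c2)cc1` gives 12700 nM in a functional assay on A549 cells (Homo sapiens) for cytotoxicity, read by MTT assay, with a stated time of 72 h; a lower number here means a stronger inhibitor, a higher number a weaker inhibitor; it is the highest of the two numbers so far, and the nearest, compound 1 `COc1cc(Nc2nc3ccccc3nc2S(=O)(=O)c2ccccc2)cc(OC)c1OC` with 9660 nM, lies within the scatter of it. Compound 3 `COc1ccc(S(=O)(=O)c2nc3ccccc3nc2Nc2cc(OC)c(OC)c(OC)c2)cc1` is not yet measured; it differs from compound 2 by methoxy in place of hydrogen on an aromatic carbon. Among the compounds with values here, no step between measured compounds isolates this change. Compound 1 already bears on that ring the methoxy pattern compound 3 would acquire, and sits within the scatter of compound 2, so the expected step from compound 2 to compound 3 is a 1.3-fold lower number from compound 2 to compound 3 (0.13 log units; within the scatter), none beyond the scatter. Compound 3 is therefore estimated at 9500 nM, range 4000 nM to 22000 nM.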

Compound 3, half-maximal inhibitory concentration: 5170 nM
Compound 3: the middle estimate sits 1.8-fold (0.26 log units) above what was measured; the range from low to high includes it.
By their numbers in this assay, from the lowest: compounds 3, 1 and 2 (each within the scatter of the next, the first and the last beyond it).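

In this assay, going by these compounds alone, methoxy in place of hydrogen ortho to two methoxy groups gives a 2.5-fold lower number from compound 2 to compound 3 (0.39 log units; beyond the scatter) and is the first step at this position to be read, modest but beyond the scatter. The methoxy addition that separates the other pair, at a different place, gives a 1.9-fold lower number from compound 1 to compound 3 (0.27 log units; within the scatter) and stays within the scatter, so it resolves no effect. Nothing measured here accounts for either step. Going by these compounds, it remains open whether ethoxy, hydroxyl or an amine at this position would match the methoxy step. On these data alone, whether the step holds in other cell lines also remains open.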